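Swapping a spiro acyl group for a methylcyclohexyl

This account rests on a few compounds, and the source may have more. Where it says the series, first, only, none or still open, it means among the compounds named here.

Compound 1 `O=C1NCCc2nc(C#Cc3ccccc3F)sc21`: > 10000 nM in an assay on HEK293 cells for negative allosteric modulation of metabotropic glutamate receptor 5 (Homo sapiens), read by FLIPR, with a stated time of 1 h (on this read-out higher numbers stand for weaker inhibition and lower numbers for stronger inhibition), a limit.
Compound 2 `CCCCN1CCc2nc(C#Cc3ccccc3)sc2C1`: > 10000 nM, a limit.
Compound 3 `O=C(C1CC12CCC2)N1CCc2nc(C#Cc3ccccc3)sc2C1`: > 10000 nM, a limit.

All three measured values sit at the limit of > 10000 nM in this assay, at which 3 of the 3 values shown sit, so none of them is a number. Compound 3 therefore stands at that limit. Within the data shown here, the only step among measured compounds, a step that the two limits leave unreadable from compound 2 to compound 3, cannot be sized, since both of its ends are limits. Compound 4 `CC1CCC(C(=O)N2CCc3nc(C#Cc4ccccc4)sc3C2)CC1` differs from compound 3 by a group of 7 heavy atoms (7 carbon; one six-membered non-aromatic ring of carbon only) in place of a group of 6 heavy atoms (6 carbon; one three-membered non-aromatic ring of carbon only, one four-membered non-aromatic ring of carbon only), on a carbonyl carbon. Among the measured compounds shown here, no measured step bears on this exchange, and nothing among the three compounds shows how far from the limit any of them lies. The expected change for this step, a number no higher from compound 3 to compound 4 (the limit leaves the size open), is none beyond the scatter. Compound 4 is therefore estimated at 10000 nM, within 3000 nM to 30000 nM, most likely again reported as a limit.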

Compound 4, half-maximal inhibitory concentration: > 10000 nM
Compound 4 was reported as a limit; the forecaster's own chance of this, stated with the estimate: 70%; the middle value lies on the limit itself.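

No step can be read from compound 3 to compound 4, because both values are limits and not numbers: the limit of > 10000 nM in this assay, at which 4 of the 4 values shown sit.
The compounds shown leave open how far each lies from that limit, and whether the 4-methylcyclohexyl group changes inhibition at all.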